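The compounds below may be only part of what the source reports. "The series", "measured", "known", "first", "only" and "open" are said of these compounds alone.

Compound 1 `CCCCOC(=O)Nc1cc2nc(C3CCCCC3)[nH]c2cc1N(C)C` has been tested in an ADME assay on Vero cells (Chlorocebus sabaeus) for cytotoxicity, read by resazurin assay, with a stated time of 3 days; a lower number here means a stronger inhibitor, a higher number a weaker inhibitor. There compound 1 gives > 100 ug/mL, which is a limit of the assay and not a number. Compound 2 `CCCCOC(=O)Nc1cc2nc(C3CCCCC3)[nH]c2cc1N(CCC)CCC` gives > 100 ug/mL, again only a limit. Among the measured compounds shown here, the one measured step, dipropylamino in place of dimethylamino on an aromatic carbon, is a step that the two limits leave unreadable from compound 1 to compound 2, and the evidence amounts to the limit of > 100 ug/mL in this assay, at which 2 of the 2 values shown sit. Compound 3 `CCCOCC(=O)Nc1cc2nc(C3CCCCC3)[nH]c2cc1N(C)C` keeps the same atoms as compound 1, joined differently: propoxymethyl in place of butoxy on a carbonyl carbon, with propoxymethyl in place of butoxy on a carbonyl carbon. For the measured compounds named here, no measured step touches that place, so the only guide is the weak effect seen in compound 1 at > 100 ug/mL. A clear step is therefore not expected, and the estimated change is a step that the limit leaves unreadable from compound 1 to compound 3, with its direction uncertain. For compound 3 the expected value is 120 ug/mL, with an estimated range from 50 ug/mL to 300 ug/mL.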

Compound 3, half-maximal inhibitory concentration: < 50 ug/mL
Compound 3: only a limit was reported (the forecaster's own chance of this, stated with the estimate: 70%); middle value at least 2.4-fold (0.38 log units) away from the limit.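

In this assay compound 3 gives < 50 ug/mL, which is a limit of the assay and not a number. Unlike the change of dipropylamino for dimethylamino, whose step cannot be read, the change on the carbonyl carbon gives a step with a readable floor, even though the same atoms are only joined differently: propoxymethyl in place of butoxy is an at least 2.0-fold lower number from compound 1 to compound 3 (0.30 log units; that floor lies within the scatter). That floor stays within the usual scatter, so the shift is suggested rather than established, and both ends of it are limits: the limit of < 50 ug/mL in this assay, at which 1 of the 3 values shown sits.

As far as these compounds go, the true size of the step remains open, as neither compound has an exact value here. From the compounds shown here alone, whether the shift follows the propoxymethyl group in particular also remains open, and a longer chain such as butoxymethyl, or an amine on the same carbonyl carbon, would test this.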